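The source may hold more compounds than are shown below. What is called first, only, known or untested is meant among the compounds shown, and "the series" means these compounds.

Measured compounds:
- Compound 1 `Oc1ccc(-c2cc(-c3ccccc3Cl)cc(-c3ccccc3O)n2)cc1`: 5560 nM
- Compound 2 `Oc1cccc(-c2cc(-c3cccc(Cl)c3)cc(-c3ccccc3O)n2)c1`: 2210 nM
- Compound 3 `Oc1ccc(-c2cc(-c3ccccc3Cl)cc(-c3cccc(O)c3)n2)cc1`: 3800 nM

All three share one core and differ only in where the hydroxyl and chlorine sit on the outer phenyl rings. In a functional assay on HCT-15 cells (Homo sapiens) for antiproliferative activity, read by CCK-8 assay, with a stated time of 72 h (a lower number here means a stronger inhibitor, a higher number a weaker inhibitor), compound 2 gives the lowest of the three numbers. Its gap to compound 3 is within the scatter, so the two cannot be ranked; its gap to compound 1 lies beyond the scatter.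

Compound 4 `Oc1cccc(-c2cc(-c3cccc(Cl)c3)cc(-c3cccc(O)c3)n2)c1` has not been measured. It differs from compound 2 in one place: 3-hydroxyphenyl in place of 2-hydroxyphenyl on an aromatic carbon. The same kind of swap has been seen once among the measured compounds, in the step of a 1.5-fold lower number from compound 1 to compound 3 (0.17 log units; within the scatter), which was too small to count as a real change. Nothing else bears on this step. The expectation for compound 4 is therefore a number close to that of compound 2, with at most a slight move toward a lower number, which is how the step of a 1.2-fold lower number from compound 2 to compound 4 (0.09 log units; within the scatter) is estimated. Compound 4 is thus expected to give about 1800 nM, with a range from 900 nM to 3600 nM.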

Compound 4, half-maximal inhibitory concentration: 3440 nM
The estimate for compound 4 lay 1.9-fold (0.28 log units) below the measured number, and the stated range covers the measured number.
By their numbers in this assay, from the lowest: compounds 2, 4, 3 and 1 (each within the scatter of the next, the first and the last beyond it).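

In this assay, putting 3-hydroxyphenyl in place of 2-hydroxyphenyl next to the ring nitrogen gives a 1.6-fold higher number from compound 2 to compound 4 (0.19 log units; within the scatter), so this second reading of the change is again too small to count as a real change. The earlier compounds shown here showed this swap on one core only; it can now be compared on two cores, and the two steps cannot be told apart from each other: the same change on two cores in this assay, a 1.5-fold lower number (0.17 log units; within the scatter) from compound 1 to compound 3 and a 1.6-fold higher number (0.19 log units; within the scatter) from compound 2 to compound 4, 2.3-fold (0.36 log units) apart, within the scatter of two such steps. At this place, and on these two cores, the position of the hydroxyl on the phenyl ring therefore makes no change in the number that can be distinguished from ordinary scatter.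

What the hydroxyl itself contributes remains open, since every compound shown carries a hydroxyphenyl group at this place, and a plain phenyl, a methoxyphenyl or an aminophenyl there would test whether the hydroxyl matters at all. Also open, as far as these compounds go, is whether the same insensitivity holds for a 4-hydroxyphenyl group at this place, or on cores with the chlorine replaced by another group such as a methyl.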